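Changing the Aryl Group on the Amide-Type Nitrogen

A few compounds are considered here, and "the series" means these few. Any claim that something is new, unique, unknown or untested is made for them only; others in the source may bear on it.

Three compounds share one core and differ only in the aryl group on an amide-type nitrogen. In a functional assay on A549 cells (Homo sapiens) for antiproliferative activity, read by MTT assay (a lower number here means a stronger inhibitor, a higher number a weaker inhibitor), compound 1 `COc1cc2ncnc(NCc3cccc(NC(=O)Nc4ccccc4C)c3)c2cc1OC` gives 21400 nM, compound 2 `COc1cc2ncnc(NCc3cccc(NC(=O)Nc4cccc(C)c4)c3)c2cc1OC` gives 27100 nM, and compound 3 `COc1ccc(NC(=O)Nc2cccc(CNc3ncnc4cc(OC)c(OC)cc34)c2)cc1` gives 24500 nM. The steps of a 1.3-fold higher number from compound 1 to compound 2 (0.10 log units; within the scatter), a 1.1-fold higher number from compound 1 to compound 3 (0.06 log units; within the scatter) and a 1.1-fold lower number from compound 2 to compound 3 (0.04 log units; within the scatter) all stay within the scatter, so compound 3, the second highest of the three numbers, is not separated from the others. Compound 4 `COc1cc2ncnc(NCc3cccc(NC(=O)Nc4ccccc4Cl)c3)c2cc1OC` differs from compound 3 by 2-chlorophenyl in place of 4-methoxyphenyl on an amide-type nitrogen. The closest guide is the step of a 1.1-fold higher number from compound 1 to compound 3 (0.06 log units; within the scatter), which also swaps the group on this nitrogen, so for compound 4 no step beyond the scatter is expected in this assay, namely a 1.1-fold lower number from compound 3 to compound 4 (0.05 log units; within the scatter). Compound 4 is therefore estimated at 22000 nM, within 10000 nM to 48000 nM.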

Compound 4, half-maximal inhibitory concentration: 15200 nM
The estimate for compound 4 lay 1.4-fold (0.16 log units) above the measured number, within the range that was stated.
By their numbers in this assay, from the lowest: compounds 4, 1, 3 and 2 (each within the scatter of the next).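

With 2-chlorophenyl on this amide-type nitrogen, a chlorine-bearing ring joins the series, and in this assay it is still not separated from the other aryl groups: a 1.6-fold lower number from compound 3 to compound 4 (0.21 log units; within the scatter), a 1.8-fold lower number from compound 2 to compound 4 (0.25 log units; within the scatter) and a 1.4-fold lower number from compound 1 to compound 4 (0.15 log units; within the scatter). That last step is the cleanest comparison, since only chloro in place of methyl on an aromatic carbon changes, and even this leaves the number within the scatter. So across these four aryl groups, this nitrogen shows no measurable preference. No measurement shown here bears on the reason for this. From the compounds shown here alone, whether an amine or a carboxylic acid on this aryl ring, or a longer chain in its place, would shift the number beyond the scatter remains open.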